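This account rests on a few compounds, and the source may have more. Where it says the series, first, only, none or still open, it means among the compounds named here.

Measured compounds:

compound 1, `CCCCCCCCCCOC(=N)NC(=N)Nc1ccc(Cl)cc1`, 6.32
compound 2, `CCCCCCCCOC(=N)NC(=N)Nc1ccc(Cl)cc1`, 5.32
compound 3, `CCCCCCNC(=N)NC(=N)Nc1ccc(C(F)(F)F)cc1`, 4.31

All three were measured in a physicochemical assay for lipophilicity, in phosphate buffer, measured as octanol-water partition, at pH 11.5; a lower number here means a more polar compound, a higher number a more lipophilic compound. Compound 1 and compound 2 share a core and differ in one place: ethyl in place of hydrogen on a saturated chain carbon, eight bonds along the chain from an oxygen on an unsaturated carbon. That change made a step of a number 1.00 log units higher from compound 2 to compound 1 (beyond the scatter). Among the measured compounds shown here, compound 3 has a different core; how the core of compound 3 differs from that of compound 2 is not broken down here, and the two values show only that compound 3 stands lower than compound 2, and lower still than compound 1.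

Compound 4, `CCCCCCCCNC(=N)NC(=N)Nc1ccc(C(F)(F)F)cc1`, has not yet been measured. It differs from compound 3 in one place: ethyl in place of hydrogen on a saturated chain carbon, six bonds along the chain from an amine nitrogen. For the measured compounds named here, this is the same kind of change as the one from compound 2 to compound 1, but not the same: in compound 1 the ethyl enters on a saturated chain carbon eight bonds along the chain from an oxygen on an unsaturated carbon, whereas in compound 4 it enters six bonds along the chain from an amine nitrogen. Among the compounds shown, this change occurs twice in all.

A step of about a number 1.00 log units higher from compound 3 to compound 4 (beyond the scatter) is expected in this assay because a number 1.00 log units higher from compound 2 to compound 1 (beyond the scatter) is the only direct measure of the change in hand. Compound 4 is therefore estimated to give 5.31, with a likely range from 4.9 to 5.7.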

Compound 4, partition coefficient: 5.31
Compound 4: middle estimate and measured number agree at the digits printed; measured number inside the range.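

In this assay the change of ethyl in place of hydrogen gave a number 1.00 log units higher from compound 3 to compound 4 (beyond the scatter) and, on the other core, a number 1.00 log units higher from compound 2 to compound 1 (beyond the scatter) in the earlier pair, so the step carried from one core to the other with its size unchanged, even though it entered six bonds along the chain from an amine nitrogen in one case and eight bonds along the chain from an oxygen on an unsaturated carbon in the other. Among the compounds shown here, this rests on only two pairs, each with one starting chain on one core, so it does not show that the step would hold on any further core, or at any other place on these chains, and it establishes no general rule for the series. Nothing given here accounts for the two steps coming out alike, and no measurement explains the size of either one.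

The compounds shown leave open whether the same difference would give a step of this size on a chain longer than that of compound 1, where the two cores might or might not continue to match. They also leave open what it would give on a chain carrying a carboxylic acid or a further amine.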